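Swapping Fluoro for Thiophene in a Serotonin Receptor Series

The source may report more compounds than this note shows. Statements on the series, on what has been measured and on what is new or still open speak of the compounds shown alone.

Compound 2 `CN1CCCN(CCn2ccc3ccc(F)cc32)CC1` gives 60% in an assay on HEK293 cells for binding affinity to 5-hydroxytryptamine receptor 7 (Homo sapiens), read by radioligand binding, tested at 1 uM (a lower number here means less inhibition, a higher number more inhibition at the concentration tested (going by the name of the read-out)), the lowest of the two measured numbers. Compound 1 `Brc1ccc2ccn(CCN3CCC4CCCCN4CC3)c2c1` gives 71% in this assay, a gap beyond the usual scatter. Compound 3 `CN1CCCN(CCn2ccc3ccc(-c4ccsc4)cc32)CC1` has not yet been measured and differs from compound 2 in one place.

thiophen-3-yl in place of fluoro on an aromatic carbon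

Going by the values given here, no pair of measured compounds shows what such a change does here. A rise beyond the scatter is nonetheless expected, with a step of a number 12 percentage points higher from compound 2 to compound 3 (beyond the scatter). Compound 3 is estimated at 72%, within a range from 52% to 88%.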

Compound 3, a percentage reported as inhibition, at one concentration (the size of the read-out at that concentration, not a potency): 68%
Compound 3: middle estimate off by 4 percentage points, on the high side; the measured number falls inside the stated range.
By their numbers in this assay, from the lowest: compounds 2, 3 and 1 (each within the scatter of the next, the first and the last beyond it).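

On an aromatic carbon of the shared core, thiophen-3-yl in place of fluoro gives a number 8 percentage points higher from compound 2 to compound 3 (within the scatter) in this assay. This position therefore accepts a group of 5 heavy atoms with its own ring in place of a single fluorine atom, and the two numbers cannot be told apart in this assay. Nothing available explains this result.

Going by these compounds, whether a smaller group, such as methoxy, or a phenyl ring would give a similar number at this position remains open. So does whether thiophen-3-yl would behave the same way on the core of compound 1.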